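Halogen exchange in the series: chloro for fluoro

The source may report more compounds than this note shows. Statements on the series, on what has been measured and on what is new or still open speak of the compounds shown alone.

Measured so far:
compound 1 `COc1cc(N/C=C\C(=O)c2cn(-c3ccccc3)nc2-c2ccccc2)cc(OC)c1OC` — 6340 nM
compound 2 `COc1cc(N/C=C\C(=O)c2cn(-c3ccccc3)nc2-c2ccc(F)cc2)cc(OC)c1OC` — 9350 nM

In a functional assay on A549 cells (Homo sapiens) for antiproliferative activity, read by MTT assay, with a stated time of 48 h (on this read-out lower numbers stand for stronger inhibition and higher numbers for weaker inhibition), compound 1 gives 6340 nM and compound 2 gives 9350 nM. Among the measured compounds shown here, compound 2 sits within the scatter of compound 1, the only other measured compound; the step of a 1.5-fold higher number from compound 1 to compound 2 (0.17 log units; within the scatter) is within the scatter. Compound 3 `COc1cc(N/C=C\C(=O)c2cn(-c3ccccc3)nc2-c2ccc(Cl)cc2)cc(OC)c1OC` carries chloro in place of fluoro on an aromatic carbon. For the measured compounds named here, no measured step covers a chloro-for-fluoro exchange; the sole halogen step, a 1.5-fold higher number from compound 1 to compound 2 (0.17 log units; within the scatter), stayed within the scatter. No shift beyond the scatter in this assay is therefore expected, and compound 3 is estimated at 9000 nM, range 3000 nM to 27000 nM, meaning a 1.0-fold lower number from compound 2 to compound 3 (0.02 log units; within the scatter).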

Compound 3, half-maximal inhibitory concentration: 5640 nM
Compound 3: middle estimate off by 1.6-fold (0.20 log units), on the high side, and the stated range covers the measured number.
By their numbers in this assay, from the lowest: compounds 3, 1 and 2 (each within the scatter of the next).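

In the series, chloro for fluoro at this position gives no separation in this assay (a 1.7-fold lower number from compound 2 to compound 3 (0.22 log units; within the scatter)), and chloro in place of hydrogen gives none either (a 1.1-fold lower number from compound 1 to compound 3 (0.05 log units; within the scatter)). Hydrogen, fluoro and chloro on this aromatic carbon, para to a large group, therefore all lie within the scatter of one another across compounds 1, 2 and 3. No supporting measurement bears on this result. From the compounds shown here alone, whether an amine or a carboxylic acid at this place would move the number beyond the scatter stays open. So does the effect of changes elsewhere on the shared core.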